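Will Methoxycarbonyl Also Stay at the Limit?

The source may hold more compounds than are shown below. What is called first, only, known or untested is meant among the compounds shown, and "the series" means these compounds.

In a toxicity assay on MDCK cells (Canis lupus familiaris) for cytotoxicity, read by CCK-8 assay, with a stated time of 48 h (a lower number here means that less compound is tolerated, a higher number that more compound is tolerated), compound 1 (`CCc1ccc(C(=O)NNc2c(Br)cccc2Br)cc1`) gives > 100000 nM as a limit and not a number. Compound 2 (`O=C(NNc1c(Br)cccc1Br)c1ccc(OCC(F)(F)F)cc1`) gives > 100000 nM as a limit as well. Compound 3 (`CC(C)(C)c1ccc(C(=O)NNc2c(Br)cccc2Br)cc1`) gives > 100000 nM as a limit too, so it has no exact place on the scale. The evidence so far comes down to the limit of > 100000 nM in this assay, at which 3 of the 3 values shown sit, and nothing finer.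

The next compound, compound 4 (`COC(=O)c1ccc(C(=O)NNc2c(Br)cccc2Br)cc1`), carries methoxycarbonyl in place of tert-butyl on an aromatic carbon, para to a large group (methoxycarbonyl in place of tert-butyl on an aromatic carbon). Three measured steps change the group at that same place. They are a step that the two limits leave unreadable from compound 1 to compound 2 together with a step that the two limits leave unreadable from compound 1 to compound 3 and also a step that the two limits leave unreadable from compound 2 to compound 3 in the same way. Within the data shown here, none of them has a readable size, so no size can be carried over, and no tested compound carries methoxycarbonyl. The expectation therefore rests on compound 3 with its limit of > 100000 nM and on little else.

The expected outcome is a number no higher from compound 3 to compound 4 (the limit leaves the size open) with no estimated change beyond the usual scatter in either direction. For compound 4 the estimate is 100000 nM with an expected range from 40000 nM to 200000 nM and a good chance of another limit.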

Compound 4, half-maximal cytotoxic concentration: 87600 nM
Compound 4: middle estimate off by 1.1-fold (0.06 log units), on the high side; the measured number falls inside the stated range.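

In this assay, methoxycarbonyl in place of tert-butyl on an aromatic carbon, para to a large group, gives the only exact number shown for this position: compound 4 gives 87600 nM. This change gives an at least 1.1-fold lower number from compound 3 to compound 4 (0.05 log units; that floor lies within the scatter), while replacing 2,2,2-trifluoroethoxy gives an at least 1.1-fold lower number from compound 2 to compound 4 (0.05 log units; that floor lies within the scatter), and replacing ethyl gives an at least 1.1-fold lower number from compound 1 to compound 4 (0.05 log units; that floor lies within the scatter). These are floors within the scatter, so they do not establish a real drop, but they do show that methoxycarbonyl, which enters with 2 hydrogen-bond acceptors where tert-butyl has 0, can sit here without a clear move away from the limit that still bounds the other compounds: the limit of > 100000 nM in this assay, at which 3 of the 4 values shown sit.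

Going by these compounds, the true size of the gaps from compound 1, compound 2 and compound 3 to compound 4 stays open, as only their lower bounds can be read. Also open, on these data alone, is whether a carboxylic acid or an amine at this place would give a number clearly lower than that of compound 4.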